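Adding ethyl to the chain of compound 2

This account rests on a few compounds, and the source may have more. Where it says the series, first, only, none or still open, it means among the compounds named here.

Measured so far in a functional assay on MCF7 cells (Homo sapiens) for inhibition, read by MTT assay, with stated times of 18 h and 4 h; a lower number here means a stronger inhibitor, a higher number a weaker inhibitor:
- compound 1 `CCCCCCCCOP(=O)(O)OCCSC(=S)N1CCCC1` gives 53000 nM
- compound 2 `CCCCCCCCOP(=O)(O)OCCSC(=S)N1CCCCC1` gives 26000 nM
- compound 3 `CCCCCCCCOP(=O)(O)OCCSC(=S)N1CCN(C)CC1` gives 46000 nM

Among the measured compounds shown here, compound 2 sits at the low end of these numbers, but it stands clear of only one neighbour: the data show a 2.0-fold lower number from compound 1 to compound 2 (0.31 log units; beyond the scatter), and also a 1.8-fold higher number from compound 2 to compound 3 (0.25 log units; within the scatter) in the same series.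

Compound 4 `CCCCCCCCCCOP(=O)(O)OCCSC(=S)N1CCCCC1` differs from compound 2 by ethyl in place of hydrogen on a saturated chain carbon, eight bonds along the chain from an oxygen on an unsaturated carbon in the chain. For the measured compounds named here, no measured step touches that chain. The largest step available, a 2.0-fold lower number from compound 1 to compound 2 (0.31 log units; beyond the scatter), changes the group on a thiocarbonyl carbon instead, so it offers only a scale. Going by the values given here, on that scale, a small move in this assay toward a lower number is expected, with a 1.7-fold lower number from compound 2 to compound 4 (0.24 log units; within the scatter) as the estimated step, and no measurement yet supports its direction. For compound 4 the estimated value is 15000 nM, with an expected range from 6000 nM to 35000 nM here.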

Compound 4, half-maximal inhibitory concentration: 7240 nM
Estimate against measurement, compound 4: 2.1-fold (0.32 log units) above, within the range that was stated.
By their numbers in this assay, from the lowest: compound 4; then compounds 2, 3 and 1 (each within the scatter of the next, the first and the last beyond it).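

The chain itself proves to be a responsive place: ethyl in place of hydrogen on this saturated chain carbon gives a 3.6-fold lower number from compound 2 to compound 4 (0.56 log units; beyond the scatter) in this assay, a step clearly beyond the scatter. Among the compounds shown here, none of the earlier steps touched the chain, and the changes on the thiocarbonyl carbon gave steps no larger than this one. No supporting evidence bears on why the number falls.

The compounds shown leave open whether a longer chain would lower the number further, or whether an amine or a carboxylic acid at this position would be tolerated. They also leave open whether ethyl gives a similar step with pyrrolidin-1-yl or 4-methylpiperazin-1-yl on the thiocarbonyl carbon.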